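A few compounds are considered here, and "the series" means these few. Any claim that something is new, unique, unknown or untested is made for them only; others in the source may bear on it.

Series notes. Three compounds of this set have been run in a functional assay on the whole organism with Mus musculus as the target (a higher number here means a larger maximal response, a lower number a smaller maximal response), and all sit low. Compound 1 `Nc1nc(O)c2c(n1)n(C1OC(CO)[C@@H](O)[C@H]1O)c(=O)n2Cc1ccc(Cl)c(Cl)c1` gives 0%, which is level at the digits shown with compound 2 `C=CCn1c(=O)n([C@@H]2O[C@H](CO)[C@H]3OC(C)(CCC(=O)NC)O[C@H]32)c2nc(N)nc(O)c21`, giving 0%, and the two together are the lowest of the three numbers. Compound 3 `CC1(C)O[C@@H]2[C@H](O1)[C@@H](CO)O[C@H]2n1c(=O)n(C/C=C/c2ccccc2)c2c(O)nc(N)nc21` gives 10%, a number higher than that of compound 1 only within the usual scatter, so no order among the three can be read from these values. Among the measured compounds shown here, no pair of measured compounds differs in a single place, so no measured single-change step is available in this assay.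

Compound 4 `CN(C)CCCn1c(=O)n(C2OC(CO)[C@@H](O)[C@H]2O)c2nc(N)nc(O)c21` is not yet measured. It differs from compound 1 as follows: 2-(dimethylamino)ethyl in place of 3,4-dichlorophenyl on a saturated chain carbon bound to an aromatic nitrogen. For the measured compounds named here, with every measured compound close to no response in this assay and no measured step to go by, nothing here points to a shift beyond the scatter. The expected step is a number 5 percentage points higher from compound 1 to compound 4 (within the scatter), none beyond the scatter. Compound 4 is therefore expected to give 5% in this assay, with a range from 0% to 25%.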

Compound 4, largest response reached (reported as maximal response), in percent of the reference or control that the assay uses: 63%
The estimate for compound 4 lay 58 percentage points below the measured number; the measured number lies above the stated range.
By their numbers in this assay, from the lowest: compounds 1, 2 and 3 (each within the scatter of the next); then compound 4.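

In this assay, 2-(dimethylamino)ethyl in place of 3,4-dichlorophenyl on a saturated chain carbon bound to an aromatic nitrogen gives a number 63 percentage points higher from compound 1 to compound 4 (beyond the scatter), so the series is no longer confined to values close to no response. Among the compounds shown here, as the only measured single-place step, it shows that this position alone can decide between almost no response and a clear one, with the sugar and the rest of the core held as in compound 1. Nothing measured here bears on the reason for this step.

The step exchanges the whole group at once, so the loss of the 3,4-dichlorobenzyl group cannot be separated from the gain of the 3-(dimethylamino)propyl group. Still open, going by these compounds, is whether a primary amine, a pyrrolidine, an unsubstituted benzyl or a longer chain ending in dimethylamino would give a comparable response at this position.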